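The compounds below may be only part of what the source reports. "The series", "measured", "known", "first", "only" and "open" are said of these compounds alone.

Measured so far:
- compound 1, `NC(=O)c1c(NC(=O)c2ccccc2Cl)sc2c1CCN(C(=S)Nc1ccccc1F)C2`: 12600 nM
- compound 2, `NC(=O)c1c(NC(=O)c2ccccc2Cl)sc2c1CCN(C(=S)Nc1ccccc1Br)C2`: 10800 nM
- compound 3, `NC(=O)c1c(NC(=O)c2ccccc2C(F)(F)F)sc2c1CCN(C(=S)Nc1ccccc1F)C2`: 19600 nM

All three were run in a functional assay on MKN-74 cells (Homo sapiens) for antiproliferative activity, with a stated time of 24 h; a higher number here means a weaker inhibitor, a lower number a stronger inhibitor. Compound 1 and compound 2 share a core and differ by bromo in place of fluoro on an aromatic carbon; the step is a 1.2-fold lower number from compound 1 to compound 2 (0.07 log units; within the scatter). Compound 3 stands apart from compound 1 through (trifluoromethyl in place of chloro on an aromatic carbon), with a step of a 1.6-fold higher number from compound 1 to compound 3 (0.19 log units; within the scatter). Going by the values given here, compound 2 and compound 3 have no step worked out between them; their two values sit within the usual scatter of each other, so no order is read from them.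

Compound 4, `NC(=O)c1c(NC(=O)c2ccccc2C(F)(F)F)sc2c1CCN(C(=S)Nc1ccccc1Br)C2`, has not been measured in this assay. It differs from compound 3 by bromo in place of fluoro on an aromatic carbon. The place description matches that of the change from compound 1 to compound 2 word for word, so this is the same change on the other core. The expected step is a 1.2-fold lower number from compound 3 to compound 4 (0.06 log units; within the scatter), which rests on the pair compound 1 to compound 2 because a 1.2-fold lower number from compound 1 to compound 2 (0.07 log units; within the scatter) fell within the scatter. Compound 4 is therefore estimated at 17000 nM in this assay, with a range from 8000 nM to 36000 nM.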

Compound 4, half-maximal inhibitory concentration: 23900 nM
Estimate against measurement, compound 4: 1.4-fold (0.15 log units) below, within the range that was stated.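

In this assay, bromo in place of fluoro gives a 1.2-fold higher number from compound 3 to compound 4 (0.09 log units; within the scatter), and this step does not differ from its counterpart on the other core: the same change on two cores in this assay, a 1.2-fold lower number (0.07 log units; within the scatter) from compound 1 to compound 2 and a 1.2-fold higher number (0.09 log units; within the scatter) from compound 3 to compound 4, 1.4-fold (0.15 log units) apart, within the scatter of two such steps

Trifluoromethyl in place of chloro gives a 2.2-fold higher number from compound 2 to compound 4 (0.34 log units; beyond the scatter), a modest step, and again the two cores do not differ: the same change on two cores in this assay, a 1.6-fold higher number (0.19 log units; within the scatter) from compound 1 to compound 3 and a 2.2-fold higher number (0.34 log units; beyond the scatter) from compound 2 to compound 4, 1.4-fold (0.15 log units) apart, within the scatter of two such steps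

These two comparisons show that both changes carried across the cores without a detectable difference, but each rests on a single pair of steps, and the bromo for fluoro steps are too small to show a shared effect, so they do not establish a general rule for the series.

From the compounds shown here alone, the four compounds vary only among fluoro, bromo, chloro and trifluoromethyl at the two changed places, so whether an amine or a carboxylic acid there would give a larger step remains open. Also open, going by these compounds, is whether either step would hold on a core with a carbonyl in place of the thiocarbonyl.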